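Swapping methoxy for chloro on the isoxazole amine scaffold

The source may report more compounds than this note shows. Statements on the series, on what has been measured and on what is new or still open speak of the compounds shown alone.

Within the data shown here, compound 1 `COc1ccc(-c2c(-c3cc(OC)c(OC)c(OC)c3)noc2N)cc1` is the only compound with a number in a functional assay on A549 cells (Homo sapiens) for cytotoxicity, read by MTT assay, with a stated time of 48 h (on this read-out higher numbers stand for weaker inhibition and lower numbers for stronger inhibition), where compound 1 gives 4490 nM. Compound 2 `COc1ccc(-c2c(-c3cc(OC)c(OC)c(OC)c3)noc2N)cc1OC` reaches only a limit in this assay, with compound 2 giving > 50000 nM. Among the measured compounds shown here, the single measured step, an at least 11-fold higher number from compound 1 to compound 2 (1.04 log units; beyond the scatter), therefore rests on the limit of > 50000 nM in this assay, at which 1 of the 2 values shown sits, and concerns a different place on the same ring than the change considered here.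

Compound 3 `COc1cc(-c2noc(N)c2-c2ccc(Cl)cc2)cc(OC)c1OC` differs from compound 1 by chloro in place of methoxy on an aromatic carbon; as a whole, the change reads 4-methoxyphenyl to 4-chlorophenyl, on an aromatic carbon of a six-membered aromatic ring of carbon only, para to a large group. For the measured compounds named here, no measured step covers this swap, so the expectation is an essentially flat step, with the limit of compound 2 as a caution that this assay can lose all signal.

Compound 3 is estimated at 6500 nM, between 2000 nM and 25000 nM, which is expected to correspond to a 1.4-fold higher number from compound 1 to compound 3 (0.16 log units; within the scatter).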

Compound 3, half-maximal inhibitory concentration: > 50000 nM
Compound 3: a limit, no number (the forecaster's own chance of this, stated with the estimate: 15%); middle value at least 7.6-fold (0.88 log units) away from the limit.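

Chloro in place of methoxy on this carbon is therefore no neutral swap, as the methoxy of compound 1 turns out to matter in this assay, with an at least 11-fold higher number from compound 1 to compound 3 (1.04 log units; beyond the scatter). The value of compound 3, > 50000 nM, is a limit and not a number, so this step gives only a lower bound on the real size of the change. Compound 1 is now the only one of the three with a number, and the changes on its ring in compound 2 and compound 3 both end at the same point: the limit of > 50000 nM in this assay, at which 2 of the 3 values shown sit.

Going by these compounds, how far compound 2 and compound 3 lie past that limit stays unknown, so the two changes cannot be ranked against each other. On these data alone, whether hydroxyl, an amine or ethoxy on this carbon would keep a number, or only methoxy does, remains open.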